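The source may hold more compounds than are shown below. What is called first, only, known or untested is meant among the compounds shown, and "the series" means these compounds.

Going by the values given here, in a functional assay on HepG2 cells (Homo sapiens) for antiproliferative activity, read by MTT assay, with a stated time of 72 h (a lower number here means a stronger inhibitor, a higher number a weaker inhibitor), two closely related compounds have numbers so far. Compound 1 `O=C(N/N=C/c1ccc([N+](=O)[O-])cc1)Nc1ccc(Oc2ccnc3[nH]ccc23)c(F)c1` gives 3030 nM, and compound 2 `O=C(N/N=C/c1ccc(Br)cc1)Nc1ccc(Oc2ccnc3[nH]ccc23)cc1` gives 1000 nM. That makes compound 2 the lower of the two and so the stronger inhibitor, with a gap beyond the usual scatter. Compound 3 `O=C(N/N=C/c1ccc([N+](=O)[O-])cc1)Nc1ccc(Oc2ccnc3[nH]ccc23)cc1` is still unmeasured. It departs from compound 2 by a single change: nitro in place of bromo on an aromatic carbon, which turns 4-bromophenyl to 4-nitrophenyl. Among the compounds with values here, no measured pair yet shows what one change alone does, so any expectation is loose. Compound 1 also carries the 4-nitrophenyl and stands at 3030 nM, which points to a modest move toward a higher number, perhaps not far beyond the scatter. The expected step is a 1.8-fold higher number from compound 2 to compound 3 (0.26 log units; within the scatter). For compound 3 the estimated value is 1800 nM, with an expected range of 700 nM to 4500 nM.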

Compound 3, half-maximal inhibitory concentration: 4620 nM
Compound 3: the middle estimate sits 2.6-fold (0.41 log units) below what was measured, and the stated range ends below it.
By their numbers in this assay, from the lowest: compound 2; then compounds 1 and 3 (each within the scatter of the next).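

In this assay, the swap of bromo for nitro gives a 4.6-fold higher number from compound 2 to compound 3 (0.66 log units; beyond the scatter), which shows that this aromatic carbon, para to a large group, is sensitive to the choice of substituent. Hydrogen in place of fluoro on an aromatic carbon gives a 1.5-fold higher number from compound 1 to compound 3 (0.18 log units; within the scatter), so this second change has no effect that can be told apart from the scatter. Nothing measured here says why the nitro compound carries the higher number.

As far as these compounds go, whether an amine, a carboxylic acid or a methoxy group at the same position would give a number lower or higher than that of compound 2 remains open. It is also unknown whether the fluoro would make as little difference in a compound carrying the 4-bromophenyl, as its effect can be read here only alongside the 4-nitrophenyl.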